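Formyl to chloro: working notes on compound 4

The source may hold more compounds than are shown below. What is called first, only, known or untested is meant among the compounds shown, and "the series" means these compounds.

The three measured compounds share one core and differ only on the six-membered aromatic ring of carbon only. Compound 1 `c1ccc(-c2cn3ccnc3c(-c3ccc4ncn(C5CCCCC5)c4c3)n2)cc1` carries hydrogen there; in a functional assay on HL-60 cells (Homo sapiens) for inhibition, read by sulforhodamine B assay, with a stated time of 48 h, tested at 10 uM (on this read-out lower numbers stand for less inhibition and higher numbers for more inhibition at the one concentration tested (going by the name of the read-out)), compound 1 gives 67.1%. Compound 2 `COc1ccc(-c2cn3ccnc3c(-c3ccc4ncn(C5CCCCC5)c4c3)n2)cc1` carries methoxy, and in this assay compound 2 gives 98.6%. Compound 3 `O=Cc1ccc(-c2cn3ccnc3c(-c3ccc4ncn(C5CCCCC5)c4c3)n2)cc1` carries formyl; in this assay compound 3 gives 16.5%, the lowest of the three numbers. All measured steps are large: a number 31.5 percentage points higher from compound 1 to compound 2 (beyond the scatter), a number 50.6 percentage points lower from compound 1 to compound 3 (beyond the scatter) and a number 82.1 percentage points lower from compound 2 to compound 3 (beyond the scatter).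

Compound 4 `Clc1ccc(-c2cn3ccnc3c(-c3ccc4ncn(C5CCCCC5)c4c3)n2)cc1` has not been measured. It differs from compound 3 by chloro in place of formyl on an aromatic carbon. Within the data shown here, no measured step introduces chloro, so the guidance is indirect: formyl entering lowers the number sharply in both a number 50.6 percentage points lower from compound 1 to compound 3 (beyond the scatter) and a number 82.1 percentage points lower from compound 2 to compound 3 (beyond the scatter), and every substituent change at this place has moved this assay beyond the scatter. Compound 4 is therefore expected to rise well above compound 3, with the step estimated as a number 48.5 percentage points higher from compound 3 to compound 4 (beyond the scatter). Where it lands relative to hydrogen or methoxy cannot be read from three compounds. For compound 4 in this assay the estimate is 65%, with a range from 35% to 95%.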

Compound 4, a percentage reported as inhibition, at one concentration (the size of the read-out at that concentration, not a potency): 15.6%
For compound 4 the middle estimate is 49.4 percentage points above the measured one; the whole stated range lies above it.
By their numbers in this assay, from the lowest: compounds 4 and 3 (each within the scatter of the next); then compound 1; then compound 2.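

In this assay the change from 4-formylphenyl to 4-chlorophenyl gives a number 0.9 percentage points lower from compound 3 to compound 4 (within the scatter) and so shows that the low level at this position is not confined to formyl: formyl brings a double bond and a hydrogen-bond acceptor and chloro neither, yet the two numbers stay within the scatter of each other. Chloro also stands apart from both other groups, with a number 51.5 percentage points lower from compound 1 to compound 4 (beyond the scatter) and a number 83 percentage points lower from compound 2 to compound 4 (beyond the scatter) as its large steps in the same assay. The position para to a large group therefore now shows two levels that are clearly apart, with compound 3 and compound 4 together under compound 1 and compound 2, although four compounds are too few to make this a rule.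

On these data alone, whether an amine, a carboxylic acid, a hydroxyl group or a longer chain at this place would sit with methoxy, with hydrogen or with formyl and chloro remains open. Nothing available gives a reason for the shared level of formyl and chloro or for the gap to methoxy.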